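From Pyrimidin-2-yl to 3-Hydroxypyridin-2-yl on the Amide Carbonyl

The source may hold more compounds than are shown below. What is called first, only, known or untested is meant among the compounds shown, and "the series" means these compounds.

Of the compounds shown here, three sharing one core have been measured in an assay on CHO cells for positive allosteric modulation of metabotropic glutamate receptor 5 (Homo sapiens), read by FLIPR; on this read-out lower numbers stand for an effect already at smaller amounts and higher numbers for an effect only at larger amounts of compound. Compound 1 `COc1cccc(C(=O)Nc2ccc(Cl)cc2CN2C(=O)c3ccccc3C2=O)c1` carries a 3-methoxyphenyl on the carbonyl carbon and gives 1500 nM. Compound 2 `O=C(Nc1ccc(Cl)cc1CN1C(=O)c2ccccc2C1=O)c1cccnc1`, with pyridin-3-yl in that place, gives 35000 nM. Compound 3 `O=C(Nc1ccc(Cl)cc1CN1C(=O)c2ccccc2C1=O)c1ncccn1`, with pyrimidin-2-yl there, gives 2100 nM. Compound 3 thus stands second highest of the three numbers, with compound 1 nearest and compound 2 furthest. The steps between them are a 23-fold higher number from compound 1 to compound 2 (1.37 log units; beyond the scatter), a 1.4-fold higher number from compound 1 to compound 3 (0.15 log units; within the scatter) and a 17-fold lower number from compound 2 to compound 3 (1.22 log units; beyond the scatter).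

Compound 4 `O=C(Nc1ccc(Cl)cc1CN1C(=O)c2ccccc2C1=O)c1ncccc1O` is the unmeasured member: 3-hydroxypyridin-2-yl in place of pyrimidin-2-yl on a carbonyl carbon. Among the measured compounds shown here, no measured step turns a pyrimidin-2-yl into a 3-hydroxypyridin-2-yl, so the steps that bear on it do so only indirectly. The large step of a 17-fold lower number from compound 2 to compound 3 (1.22 log units; beyond the scatter) shows that the choice of six-membered aromatic ring on this carbonyl carbon can move this assay strongly, whereas a 1.4-fold higher number from compound 1 to compound 3 (0.15 log units; within the scatter) shows that two quite different rings can also land within the scatter. With nothing closer to go on, a step of modest size, in either direction and probably not beyond the scatter, is expected. Compound 4 is therefore estimated at 2500 nM, with a range from 700 nM to 12000 nM. The expected step is a 1.2-fold higher number from compound 3 to compound 4 (0.08 log units; within the scatter).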

Compound 4, half-maximal effective concentration: 260 nM
Compound 4: the middle estimate sits 9.6-fold (0.98 log units) above what was measured, outside the stated range (below it).
By their numbers in this assay, from the lowest: compound 4; then compounds 1 and 3 (each within the scatter of the next); then compound 2.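

In this assay, among the compounds shown here, the 3-hydroxypyridin-2-yl is the first group on this carbonyl carbon to bring the number clearly under the level that the 3-methoxyphenyl and pyrimidin-2-yl compounds share within the scatter, with an 8.1-fold lower number from compound 3 to compound 4 (0.91 log units; beyond the scatter) and a 5.8-fold lower number from compound 1 to compound 4 (0.76 log units; beyond the scatter). The earlier compounds showed only that a change of ring here could raise the number or leave it within the scatter; this result shows that the position also allows a real drop, and a 130-fold lower number from compound 2 to compound 4 (2.13 log units; beyond the scatter) widens the span seen among these rings. No evidence at hand accounts for this drop.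

The entering group has one ring hetero atom fewer than the pyrimidin-2-yl and counts 1 hydrogen-bond donor where the leaving group counts 0, and the compounds shown do not separate these two differences. They also leave open how a methoxy, an amine or a fluorine in place of the hydroxy on the same pyridin-2-yl ring would stand in this assay.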